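The compounds below may be only part of what the source reports. "The series", "measured", "known", "first", "only" and "open" are said of these compounds alone.

Working notes on the series, values in a functional assay (aorta) for inhibition, with Rattus norvegicus as the target; a higher number here means a weaker inhibitor, a lower number a stronger inhibitor:

- compound 1 `CC(/N=C(\NC#N)Nc1ccccc1)C(C)(C)C`: 980 nM
- compound 2 `CC(C)(C)/N=C(\NC#N)Nc1ccc(C#N)cc1`: 530 nM
- compound 3 `CC(C)/N=C(\NC#N)Nc1ccc(C#N)cc1`: 19000 nM

Compound 1 at 980 nM lies within the scatter of compound 2 at 530 nM. Compound 3 stands clearly apart from both, with a higher number.

The next step leads to compound 4 `CC(/N=C(\NC#N)Nc1cccc(C#N)c1)C(C)(C)C`, which keeps the chain of compound 1 and has cyano in place of hydrogen on an aromatic carbon, meta to a large group (cyano in place of hydrogen on an aromatic carbon).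

Among the measured compounds shown here, the one measured step, a 36-fold higher number from compound 2 to compound 3 (1.55 log units; beyond the scatter), is large but changes the chain, so it bears only indirectly on this ring change. For the measured compounds named here, no measured step isolates a cyano on the ring. The nearest hint is compound 2, which holds a ring cyano at 530 nM but differs from compound 1 in its chain as well.

Only a small shift towards a lower number is therefore expected, probably not beyond the scatter. The estimated change is a 1.6-fold lower number from compound 1 to compound 4 (0.21 log units; within the scatter). For compound 4 the expected value is 600 nM, with an estimated range from 130 nM to 2500 nM.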

Compound 4, half-maximal inhibitory concentration: 190 nM
Compound 4: middle estimate off by 3.2-fold (0.50 log units), on the high side; measured number inside the range.
By their numbers in this assay, from the lowest: compound 4; then compounds 2 and 1 (each within the scatter of the next); then compound 3.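

In this assay, among the compounds shown here, cyano in place of hydrogen on an aromatic carbon, meta to a large group, gives a 5.2-fold lower number from compound 1 to compound 4 (0.71 log units; beyond the scatter) and is the only measured step that isolates a ring change. With the chain of compound 1 held fixed, the step lies beyond the scatter, so the number in this series responds to a change at this ring position as well as to the chain change seen earlier. No measurement at hand explains the shift.

From the compounds shown here alone, it remains open whether another group at this position, such as a methoxy group, an amine or a carboxylic acid, would shift the number in the same direction as cyano. Compound 2 and compound 4 differ in more than one place, so the effect of where the cyano sits on the ring cannot be separated from the effect of the chain.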